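This account rests on a few compounds, and the source may have more. Where it says the series, first, only, none or still open, it means among the compounds named here.

In a functional assay on A-431 cells (Homo sapiens) for antiproliferative activity, read by CCK-8 assay, with a stated time of 72 h (a lower number here means a stronger inhibitor, a higher number a weaker inhibitor), compound 1 `C#Cc1cccc(Nc2ncnc3cc(OCCOC)c(OCCOC(=O)c4ccccc4OC(C)=O)cc23)c1` gives > 10000 nM, which is a limit and not a number. Compound 2 `C#Cc1cccc(Nc2ncnc3cc(OCCOC)c(OCCOC(=O)C(C)c4ccc(CC(C)C)cc4)cc23)c1` gives > 10000 nM, which is also only a limit. The data so far therefore come down to the limit of > 10000 nM in this assay, at which 2 of the 2 values shown sit. Compound 3 `C#Cc1cccc(Nc2ncnc3cc(OCCOC)c(OCCOC(=O)C(C)c4ccc5cc(OC)ccc5c4)cc23)c1` keeps the shared core of compound 2 and changes one group: 6-methoxynaphthalen-2-yl in place of 4-isobutylphenyl on a saturated chain carbon bound to a carbonyl carbon and a saturated chain carbon. Here 6-methoxynaphthalen-2-yl comes in place of 4-isobutylphenyl on a saturated chain carbon bound to a carbonyl carbon and a saturated chain carbon. Among the measured compounds shown here, the only measured step that bears on this is a step that the two limits leave unreadable from compound 1 to compound 2, which offers no size to carry over. No step beyond the scatter is therefore expected in this assay, and no direction can be argued. The expected step is a step that the limit leaves unreadable from compound 2 to compound 3. For compound 3 the estimated value is 12000 nM, with an expected range from 5000 nM to 30000 nM.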

Compound 3, half-maximal inhibitory concentration: 5000 nM
Compound 3: the middle estimate sits 2.4-fold (0.38 log units) above what was measured; measured number inside the range.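

In this assay compound 3 gives 5000 nM, the only value among the compounds shown that is a number and not a limit, so 6-methoxynaphthalen-2-yl gives this position its first readable result. The change is an at least 2.0-fold lower number from compound 2 to compound 3 (0.30 log units; that floor lies within the scatter), which means the data do not establish a difference beyond the scatter, even though compound 3 has a measured value. The step between the earlier compounds cannot be read, and the limit still describes most of the set: the limit of > 10000 nM in this assay, at which 2 of the 3 values shown sit.

The compounds shown do not separate the contribution of the methoxy group from that of the second aromatic ring, which a plain naphthalen-2-yl or a hydroxy group in place of methoxy would address. They also leave open whether the ester linkage matters, which an amide in its place would test.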